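From chloro to methylsulfanyl on the allyl-bearing core

The compounds below may be only part of what the source reports. "The series", "measured", "known", "first", "only" and "open" are said of these compounds alone.

In a functional assay on aorta with Alpha-1D adrenergic receptor (Rattus norvegicus) as the target (on this read-out lower numbers stand for an effect already at smaller amounts and higher numbers for an effect only at larger amounts of compound), compound 1 `CCn1nc(Cc2ccc(SC)cc2)c2ccccc2c1=O` gives > 100000 nM.
In this assay compound 2 `CSc1ccc(Cc2nn(-c3ccccc3)c(=O)c3ccccc23)cc1` gives > 100000 nM.
In this assay compound 3 `C=CCn1nc(Cc2ccc(Cl)cc2)c2ccccc2c1=O` gives 2600 nM.

The value of compound 1 is a limit of the assay, not a number. The same holds for compound 2. In this assay, going by the values given here, compound 3 therefore gives the only number among the three. Compound 4 `C=CCn1nc(Cc2ccc(SC)cc2)c2ccccc2c1=O` differs from it by methylsulfanyl in place of chloro on an aromatic carbon. Among the compounds with values here, the single measured step, a step that the two limits leave unreadable from compound 1 to compound 2, concerns a different position and cannot be read. What remains is that compound 1 and compound 2, both carrying methylsulfanyl, sit at the limit of > 100000 nM in this assay, at which 2 of the 3 values shown sit. A weakening step a 12-fold higher number from compound 3 to compound 4 (1.06 log units; beyond the scatter) is therefore expected. Compound 4 is estimated at 30000 nM, between 5000 nM and 100000 nM, with a fair chance that only a limit is reported.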

Compound 4, half-maximal effective concentration: > 100000 nM
Compound 4 was reported as a limit; the forecaster's own chance of this, stated with the estimate: 40%; middle value at least 3.3-fold (0.52 log units) from the limit.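

In this assay, methylsulfanyl in place of chloro on the aromatic carbon gives an at least 38-fold higher number from compound 3 to compound 4 (1.58 log units; beyond the scatter), with the allyl group on the nitrogen unchanged. Going by these compounds alone, this is the first readable step at this position, and it isolates a single change, which the earlier compounds could not do. All three compounds carrying methylsulfanyl now end at the same assay limit: the limit of > 100000 nM in this assay, at which 3 of the 4 values shown sit.

Going by these compounds, the steps among those three cannot be read, so the effect of the nitrogen substituent alongside methylsulfanyl stays unknown. On these data alone, whether methoxy, fluoro or an amine at this position would give a measurable value also remains open.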